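From hexyl to benzyl on compound 2

The source may report more compounds than this note shows. Statements on the series, on what has been measured and on what is new or still open speak of the compounds shown alone.

Results so far in an ADME assay on cells (Macrophage) for cytotoxicity, read by resazurin assay, with a stated time of 48 h (a higher number here means that more compound is tolerated, a lower number that less compound is tolerated), are these
- compound 1 `COc1ccc(-c2cc(-c3ccc(OCc4cn(Cc5ccccc5)nn4)cc3O)nc(N)n2)cc1` gives 42700 nM
- compound 2 `CCCCCCn1cc(COc2ccc3c(c2)OC(c2ccc(C(C)C)cc2)CC3=O)nn1` gives "not determined" (no result reported)
- compound 3 `CCCCCCn1cc(COc2ccc3c(c2)OC(c2ccccc2)CC3=O)nn1` gives "not determined" (no result reported)

Only one of these compounds carries a number. Compound 2 has no single value to stand on, since its entry reads "not determined" (no result reported) and gives no figure to compare. The same holds for compound 3, whose entry is "not determined" (no result reported) as well.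

Compound 4 (`CC(C)c1ccc(C2CC(=O)c3ccc(OCc4cn(Cc5ccccc5)nn4)cc3O2)cc1`) still awaits measurement. Within the data shown here, the one structural change that leads to it is phenyl in place of pentyl on a saturated chain carbon bound to an aromatic nitrogen and it puts phenyl in place of pentyl on a saturated chain carbon bound to an aromatic nitrogen. Cut one bond further out, the same difference reads hexyl to benzyl.

Among the measured compounds shown here, with no number for compound 2, the size of this step cannot be read from the data, and no measured step exists to borrow from. No step beyond the usual scatter of this assay is expected, in either direction. For the measured compounds named here, the only guide is compound 1 at 42700 nM as a value, which also carries benzyl, although its core differs. The estimated value for compound 4 is 40000 nM with an expected range from 12000 nM to 130000 nM as its ends.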

Compound 4, half-maximal cytotoxic concentration: 23800 nM
Compound 4: middle estimate off by 1.7-fold (0.23 log units), on the high side; low and high end bracket the measured number.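

No step can be read from compound 2 to compound 4: in this assay compound 4 gives 23800 nM while compound 2 has no figure to set against it. The compounds shown leave open how the change from hexyl to benzyl shifts the tolerated concentration on a shared core. Nothing shown offers an explanation for the value of compound 4.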